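A few compounds are considered here, and "the series" means these few. Any claim that something is new, unique, unknown or untested is made for them only; others in the source may bear on it.

In a functional assay on COLO 205 cells (Homo sapiens) for inhibition, read by sulforhodamine B assay, with a stated time of 48 h, tested at 10 uM (a higher number here means a weaker effect of the compound at the concentration tested, a lower number a stronger effect), compound 1 `COc1cc2cc(Oc3ccc(NC(=O)Nc4cccc(C(F)(F)F)c4)cc3)c(C)nc2cc1OC` gives -20.2%, while compound 2 `COc1cc2cc(Oc3ccc(NC(=O)Nc4ccc(Cl)c(C(F)(F)F)c4)cc3)c(C)nc2cc1OC` gives -49.6%, the lowest of the two numbers; the two are separated by a step of a number 29.4 percentage points lower from compound 1 to compound 2 (beyond the scatter). Compound 3 `COc1cc2cc(Oc3ccc(NC(=O)Nc4ccc(Cl)c(Cl)c4)cc3)c(C)nc2cc1OC` differs from compound 2 by chloro in place of trifluoromethyl on an aromatic carbon. For the measured compounds named here, the only measured step concerns a different change, chloro replacing hydrogen, and so offers no direct guide to this one; on that basis no shift beyond the scatter is expected for compound 3, that is a step of a number 7.6 percentage points higher from compound 2 to compound 3 (within the scatter) is estimated. Compound 3 is therefore expected to give -42% in this assay, within a range from -62% to -18%.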

Compound 3, a percentage reported as activity, at one concentration (the size of the read-out at that concentration, not a potency): 4.03%
Estimate against measurement, compound 3: 46 percentage points below, and the stated range ends below it.
By their numbers in this assay, from the lowest: compound 2; then compound 1; then compound 3.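

In this assay, chloro does not stand in for trifluoromethyl at this place, ortho to a chloro group, and the swap gives a number 53.6 percentage points higher from compound 2 to compound 3 (beyond the scatter). The comparison with the compound lacking the chloro group gives a number 24.2 percentage points higher from compound 1 to compound 3 (beyond the scatter), so among these three, compound 3 shows the weakest effect and the 4-chloro substituent does not make up for the loss of trifluoromethyl. Nothing available explains this result. On these data alone, whether a bromo, a methoxy or a nitrile at this place would behave like trifluoromethyl or like chloro remains open.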